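Halogen swap on the fused ring of compound 2

A few compounds are considered here, and "the series" means these few. Any claim that something is new, unique, unknown or untested is made for them only; others in the source may bear on it.

The series shares one core, varied so far only at the saturated chain carbon bound to the amide-type nitrogen in the ring. Compound 1 `CCN(CC)CN1C(=O)/C(=N\c2nc3ccc(C)cc3s2)c2c(Br)cccc21` carries diethylamino there and in a functional assay on MDA-MB-468 cells (Homo sapiens) for cytotoxicity, read by sulforhodamine B assay, with a stated time of 48 h (a higher number here means a weaker inhibitor of growth, a lower number a stronger inhibitor of growth), compound 1 gives 43100 nM. Compound 2 `Cc1ccc2nc(/N=C3\C(=O)N(CN(C)C)c4cccc(Br)c43)sc2c1` carries dimethylamino and compound 2 gives 27400 nM. Compound 3 `Cc1ccc2nc(/N=C3\C(=O)N(CN4CCCCC4)c4cccc(Br)c43)sc2c1` carries piperidin-1-yl and compound 3 gives 24000 nM. The three steps, a 1.6-fold lower number from compound 1 to compound 2 (0.20 log units; within the scatter), a 1.8-fold lower number from compound 1 to compound 3 (0.25 log units; within the scatter) and a 1.1-fold lower number from compound 2 to compound 3 (0.06 log units; within the scatter), all stay within the scatter, so the group on that carbon has not moved the numbers. Compound 2 stands second highest of the three values; its nearest neighbour is compound 3 and its furthest is compound 1, both within the scatter.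

Compound 4 `Cc1ccc2nc(/N=C3\C(=O)N(CN(C)C)c4cccc(Cl)c43)sc2c1` differs from compound 2 by chloro in place of bromo on an aromatic carbon. Among the measured compounds shown here, none of the three measured steps touches the substituent on the aromatic carbon, so the series holds no direct precedent for this change. For the measured compounds named here, with every measured variation lying within the scatter and no measured step bearing on this position, the expectation is a step of no more than the scatter in this assay, in either direction; the expected step is a 1.1-fold higher number from compound 2 to compound 4 (0.04 log units; within the scatter). Compound 4 is therefore expected to give 30000 nM, with a range from 12000 nM to 80000 nM.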

Compound 4, concentration for 50% growth inhibition: 28100 nM
Compound 4: middle estimate off by 1.1-fold (0.03 log units), on the high side; measured number inside the range.
By their numbers in this assay, from the lowest: compounds 3, 2, 4 and 1 (each within the scatter of the next).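

In this assay, the first measured variation on the aromatic carbon, ortho to a fused ring and meta to a fused ring, gives a 1.0-fold higher number from compound 2 to compound 4 (0.01 log units; within the scatter), so chloro and bromo cannot be told apart at this position. The earlier compounds shown here varied only the amine on the saturated chain carbon; this step shows the same absence of a measurable effect at a second place on the shared core, though only for this one exchange and only with dimethylamino on the chain carbon. No measurement bearing on this result is available, so the likeness of the two numbers stays unexplained.

On these data alone, what a hydrogen, a methoxy group, an amine or a carboxylic acid on that aromatic carbon would do remains open, so the response of this position beyond the two halogens is unknown. Also open, as far as these compounds go, are whether chloro reads the same with diethylamino or piperidin-1-yl on the chain carbon, and whether any group at either place can carry the number beyond the scatter.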